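The source may report more compounds than this note shows. Statements on the series, on what has been measured and on what is new or still open speak of the compounds shown alone.

In a functional assay on HCT-116 cells (Homo sapiens) for antiproliferative activity, read by MTT assay, with a stated time of 72 h (a lower number here means a stronger inhibitor, a higher number a weaker inhibitor), compound 1 (`COc1ccc(N2C(=O)COc3ccc(-c4ccc(O)cc4)cc32)cc1`) gives 26100 nM and compound 2 (`COc1ncc(-c2ccc3c(c2)NC(=O)CO3)cc1NS(=O)(=O)c1ccc(F)cc1`) gives 24900 nM as its reading, two values within the scatter of each other. Compound 2 therefore stands level with compound 1. Compound 3 (`COc1ncc(-c2ccc3c(c2)N(C2CCCCC2)C(=O)CO3)cc1NS(=O)(=O)c1ccc(F)cc1`) differs from compound 2 in one place (cyclohexyl in place of hydrogen on an amide-type nitrogen in a ring): cyclohexyl in place of hydrogen on an amide-type nitrogen in a ring. Among the measured compounds shown here, no step between measured compounds sizes this change. Compound 1 also bears a group rather than hydrogen on an amide-type nitrogen in a ring, yet its value of 26100 nM sits within the scatter of the reading for compound 2, though the two differ elsewhere too. In this assay a 1.8-fold lower number from compound 2 to compound 3 (0.25 log units; within the scatter) is therefore expected to be modest, toward a lower number and close to the scatter. Compound 3 is estimated at 14000 nM with a range from 4000 nM to 40000 nM in that read-out.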

Compound 3, half-maximal inhibitory concentration: > 40000 nM
Compound 3: no number, only a limit (the forecaster's own chance of this, stated with the estimate: 15%); middle value at least 2.8-fold (0.45 log units) from the limit.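

In this assay, the amide-type nitrogen of the shared core now has a measured step of its own, with cyclohexyl in place of hydrogen giving an at least 1.6-fold higher number from compound 2 to compound 3 (0.20 log units; that floor lies within the scatter) at this position. Cyclohexyl on this nitrogen therefore brings no lower number, although the floor of the step does not by itself separate the two compounds beyond the scatter. Compound 3 reads only as a limit, not as a number: the limit of > 40000 nM in this assay, at which 1 of the 3 values shown sits.

As far as these compounds go, how far past that limit compound 3 lies stays open, so the full size of the step cannot be read. Also open, from the compounds shown here alone, is whether a smaller group on this nitrogen, such as methyl, or a chain ending in an amine, such as aminoethyl, would read differently from hydrogen or cyclohexyl in this assay.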